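Shifting a Methyl Group on the Amide Aryl Ring

The compounds below may be only part of what the source reports. "The series", "measured", "known", "first", "only" and "open" are said of these compounds alone.

In a functional assay on 143B cells (Homo sapiens) for antiproliferative activity, read by MTT assay, with a stated time of 48 h (a lower number here means a stronger inhibitor, a higher number a weaker inhibitor), compound 2 `Cc1ccccc1C(=O)Nc1cccc(/C=C/C(=O)c2nc3ccccc3[nH]2)c1` gives 8290 nM. Compound 1 `O=C(Nc1cccc(/C=C/C(=O)c2nc3ccccc3[nH]2)c1)c1cccc(Br)c1` gives 4620 nM, and the two values lie within the scatter of each other. Compound 3 `Cc1cccc(C(=O)Nc2cccc(/C=C/C(=O)c3nc4ccccc4[nH]3)c2)c1` has not been measured; it differs from compound 2 by 3-methylphenyl in place of 2-methylphenyl on a carbonyl carbon. Going by the values given here, the only measured step that bears on a change at that carbonyl carbon is a 1.8-fold higher number from compound 1 to compound 2 (0.25 log units; within the scatter), which stayed within the scatter. The expected step is therefore a 1.2-fold lower number from compound 2 to compound 3 (0.07 log units; within the scatter), nothing beyond the scatter. Compound 3 is estimated to give about 7000 nM, within a range from 3000 nM to 17000 nM.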

Compound 3, half-maximal inhibitory concentration: 4880 nM
Estimate against measurement, compound 3: 1.4-fold (0.16 log units) above, within the range that was stated.
By their numbers in this assay, from the lowest: compounds 1, 3 and 2 (each within the scatter of the next).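

In this assay, moving the methyl group gives a 1.7-fold lower number from compound 2 to compound 3 (0.23 log units; within the scatter) and stays within the scatter, so neither 2-methylphenyl nor 3-methylphenyl on the carbonyl carbon stands apart here. Swapping bromo for methyl on the aromatic carbon gives a 1.1-fold higher number from compound 1 to compound 3 (0.02 log units; within the scatter) and also stays within the scatter, which means the 3-substituted pair cannot be told apart either. Nothing available here offers an explanation for these results. As far as these compounds go, whether an amine or a carboxylic acid on this aryl ring would move the number beyond the scatter remains open.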